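The source may hold more compounds than are shown below. What is called first, only, known or untested is meant among the compounds shown, and "the series" means these compounds.

Compound 1 `Cc1ccccc1-n1nncc1CN1C(=O)C2(C(C#N)=C(N)Oc3c(N)cc4nc5ccccc5nc4c32)c2ccccc21`: > 50000 nM
Compound 2 `N#CC1=C(N)Oc2c(N)cc3nc4ccccc4nc3c2C12C(=O)N(Cc1cnnn1-c1ccc(Cl)cc1)c1ccccc12`: > 50000 nM
Compound 3 `CCOc1ccc(-n2nncc2CN2C(=O)C3(C(C#N)=C(N)Oc4c(N)cc5nc6ccccc6nc5c43)c3ccccc32)cc1`: > 50000 nM

The three measured compounds share one core and differ only in the aryl group on an aromatic nitrogen of the triazole. In a functional assay on HCT-116 cells (Homo sapiens) for antiproliferative activity, read by MTT assay, with a stated time of 48 h (on this read-out higher numbers stand for weaker inhibition and lower numbers for stronger inhibition), compound 1 reaches only an assay limit, > 50000 nM. Compound 2 likewise gives only a limit in this assay, > 50000 nM. Compound 3, the starting point here, also stands at a limit in this assay, > 50000 nM, so no number for it is known. The three pairwise steps, a step that the two limits leave unreadable from compound 1 to compound 2, a step that the two limits leave unreadable from compound 1 to compound 3 and a step that the two limits leave unreadable from compound 2 to compound 3, therefore cannot be read, as all three values sit at the limit of > 50000 nM in this assay, at which 3 of the 3 values shown sit.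

Compound 4 `CCc1cccc(CC)c1-n1nncc1CN1C(=O)C2(C(C#N)=C(N)Oc3c(N)cc4nc5ccccc5nc4c32)c2ccccc21` is the next compound in this series, and it differs from compound 3 as follows: 2,6-diethylphenyl in place of 4-ethoxyphenyl on an aromatic nitrogen. Every measured step touches the same position, yet none of them gives a readable size or direction, so the measured data offer no basis for expecting a gain. The expectation for compound 4 is therefore that it too remains at the assay limit, and the step from compound 3 is estimated as a step that the limit leaves unreadable from compound 3 to compound 4. On that basis compound 4 is estimated at 80000 nM in this assay, within a range from 25000 nM to 300000 nM.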

Compound 4, half-maximal inhibitory concentration: 37600 nM
Compound 4: middle estimate off by 2.1-fold (0.33 log units), on the high side; low and high end bracket the measured number.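

Going by these compounds alone, compound 4 is the first at this aromatic nitrogen to give a number rather than a limit in this assay, so 2,6-diethylphenyl shows that this position can yield a readable value: the limit of > 50000 nM in this assay, at which 3 of the 4 values shown sit. The change to 2,6-diethylphenyl gives an at least 1.3-fold lower number from compound 3 to compound 4 (0.12 log units; that floor lies within the scatter) and an at least 1.3-fold lower number from compound 2 to compound 4 (0.12 log units; that floor lies within the scatter) and an at least 1.3-fold lower number from compound 1 to compound 4 (0.12 log units; that floor lies within the scatter). These are floors only, so none of the three steps establishes a gain, and the steps among compound 1, compound 2 and compound 3 still cannot be read.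

The compounds shown leave open how far the true values of the limited compounds lie from that of compound 4. They also leave open whether a single ethyl group, a longer chain, an isopropyl group or an amine on the phenyl ring would shift the value further.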